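The compounds below may be only part of what the source reports. "The series", "measured", "known", "first", "only" and "open" are said of these compounds alone.

Measured in a functional assay on HCT-116 cells (Homo sapiens) for inhibition, read by MTT assay, with a stated time of 2 days (a higher number here means a weaker inhibitor of growth, a lower number a stronger inhibitor of growth), the compounds read as follows:

- compound 1 `Nc1ccccc1NC(=O)CCCNCC(=O)Nc1ccc(Br)cc1` gives 55500 nM
- compound 2 `Nc1ccccc1NC(=O)CCCNCC(=O)Nc1cccc([N+](=O)[O-])c1` gives 22500 nM
- compound 3 `Nc1ccccc1NC(=O)c1ccc(NCC(=O)Nc2cccc([N+](=O)[O-])c2)cc1` gives 9000 nM

Of the three, compound 3 has the lowest number at 9000 nM and lies clearly below the other two. Compound 4 `COc1ccc(NC(=O)CNc2ccc(C(=O)Nc3ccccc3N)cc2)cc1` differs from compound 3 in one place (4-methoxyphenyl in place of 3-nitrophenyl on an amide-type nitrogen), with 4-methoxyphenyl in place of 3-nitrophenyl on an amide-type nitrogen. Among the measured compounds shown here, only one measured step bears on this change: a 2.5-fold lower number from compound 1 to compound 2 (0.39 log units; beyond the scatter) as 3-nitrophenyl replaces 4-bromophenyl on an amide-type nitrogen. That step is modest and was measured on the core of compound 2, not on the core of compound 3. For the measured compounds named here, no measured compound carries 4-methoxyphenyl. Going by compound 2 (22500 nM) against compound 1 (55500 nM), giving up 3-nitrophenyl is expected to raise the number modestly in this assay rather than lower it. The estimate is a 1.8-fold higher number from compound 3 to compound 4 (0.25 log units; within the scatter) as an expected step of modest size. Compound 4 is expected at 16000 nM within an estimated range of 6000 nM to 40000 nM in this measurement.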

Compound 4, concentration for total growth inhibition: 38000 nM
Compound 4: the middle estimate sits 2.4-fold (0.38 log units) below what was measured; the measured number falls inside the stated range.
By their numbers in this assay, from the lowest: compound 3; then compounds 2, 4 and 1 (each within the scatter of the next, the first and the last beyond it).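

In this assay, the group on the amide-type nitrogen now shows a measured effect on a second core: with 4-methoxyphenyl in place of 3-nitrophenyl, the result is a 4.2-fold higher number from compound 3 to compound 4 (0.63 log units; beyond the scatter). Among the compounds shown here, the only earlier step at this place, a 2.5-fold lower number from compound 1 to compound 2 (0.39 log units; beyond the scatter), was read on a different core and against 4-bromophenyl; in both pairs, the compound carrying 3-nitrophenyl has the lower number, a direction supported by these two pairs alone. No evidence is available to explain this step.

The compounds shown leave open whether the nitro group or its place on the ring accounts for the difference, a question that 4-nitrophenyl or 3-methoxyphenyl at this nitrogen could address. On these data alone, how a plain phenyl or a carboxylic acid-bearing phenyl would read on either core also remains open.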